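The source may report more compounds than this note shows. Statements on the series, on what has been measured and on what is new or still open speak of the compounds shown alone.

Measured compounds:

- compound 1, `COc1ccccc1S(=O)(=O)/C=C/c1ncccc1F`, 99.2%
- compound 2, `COc1ccccc1S(=O)(=O)/C=C/c1ncccc1Cl`, 100%
- compound 3, `COc1ccc(S(=O)(=O)/C=C/c2ncccc2F)cc1`, 86.6%

All three were tested in an ADME assay on BV-2 cells (Mus musculus) for cytotoxicity, with a stated time of 24 h, tested at 50 uM; a lower number here means a stronger effect, a higher number a weaker effect of the compound at the concentration tested. Compound 1 and compound 2 share a core and differ only in one place: chloro in place of fluoro on an aromatic carbon. The step of a number 0.8 percentage points higher from compound 1 to compound 2 (within the scatter) shows that this exchange left the read-out essentially where it was, since the gap lies within the usual scatter of the measurement, so no change in effect can be claimed between compound 1 and compound 2.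

Compound 3 has the same atoms as compound 1, joined differently; the difference between the two cores is not broken down here. In this assay compound 3 gives the lowest of the three numbers, and its distance from both compound 1 and compound 2 is beyond the scatter.

Compound 4, `COc1ccc(S(=O)(=O)/C=C/c2ncccc2Cl)cc1`, has not yet been measured. It stands to compound 3 exactly as compound 2 stands to compound 1: chloro in place of fluoro on an aromatic carbon. The place of the change is described in the same words for both pairs, so it is the same change on a different core. For the measured compounds named here, the only measured example of this change, a number 0.8 percentage points higher from compound 1 to compound 2 (within the scatter), made no real difference. On that basis the expected step is a number 1.4 percentage points higher from compound 3 to compound 4 (within the scatter), which is to say that compound 4 is estimated to stay close to compound 3. The estimate for compound 4 in this assay is 88%, with a plausible range from 75% to 100%.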

Compound 4, a percentage reported as activity, at one concentration (the size of the read-out at that concentration, not a potency): 89.8%
For compound 4 the middle estimate is 1.8 percentage points below the measured one; low and high end bracket the measured number.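

Putting chloro in place of fluoro on an aromatic carbon gave a number 3.2 percentage points higher from compound 3 to compound 4 (within the scatter) in this assay, so on this second core the exchange again left the read-out essentially where it was. Set side by side, the two examples of the change do not differ from each other: the same change on two cores in this assay, a number 0.8 percentage points higher (within the scatter) from compound 1 to compound 2 and a number 3.2 percentage points higher (within the scatter) from compound 3 to compound 4, 2.4 percentage points apart, within the scatter of two such steps This shows that, for these two cores, the exchange carried over from one to the other without a difference that can be told from the scatter, but it rests on only two pairs, and neither shows a real effect. A change that does nothing on two cores is therefore a weak test of transfer: it does not show that a change with a clear effect would carry over in the same way, and it does not explain why the read-out stayed put.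

The compounds shown cover only fluoro and chloro at this place, so it remains open what a bromo, a nitrile or an amine on the same aromatic carbon would do to the read-out. As far as these compounds go, it is also open whether the exchange would stay this quiet on a core other than these two, or at a different concentration.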